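Working notes on cytotoxicity across a small sulfonamide series

The compounds below may be only part of what the source reports. "The series", "measured", "known", "first", "only" and "open" are said of these compounds alone.

Measured in an ADME assay on Vero 76 cells (Chlorocebus sabaeus) for cytotoxicity, read by MTT assay, with a stated time of 96 h; on this read-out lower numbers stand for higher toxicity in this test and higher numbers for lower toxicity in this test:
compound 1 `NS(=O)(=O)c1ccc(N2N=C(c3ccccc3)CC2c2ccccc2Cl)cc1` gives 26000 nM
compound 2 `NS(=O)(=O)c1ccc(N2N=C(c3ccc(Oc4ccccc4)cc3)CC2c2ccccc2Cl)cc1` gives 29000 nM
compound 3 `Cc1ccccc1C1CC(c2ccc(Oc3ccccc3)cc2)=NN1c1ccc(S(N)(=O)=O)cc1` gives 90000 nM

Two single changes connect the measured compounds. From compound 2 to compound 1 the change is hydrogen in place of phenoxy on an aromatic carbon and the step in this assay is a 1.1-fold lower number from compound 2 to compound 1 (0.05 log units; within the scatter), so the two compounds are indistinguishable on this read-out. From compound 2 to compound 3 the change is methyl in place of chloro on an aromatic carbon and the step is a 3.1-fold higher number from compound 2 to compound 3 (0.49 log units; beyond the scatter); compound 3 thereby stands highest of the three, beyond the scatter from both others.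

Compound 4 `Cc1ccccc1C1CC(c2ccccc2)=NN1c1ccc(S(N)(=O)=O)cc1` is not yet measured. It differs from compound 3 by hydrogen in place of phenoxy on an aromatic carbon. This is the same change that was made from compound 2 to compound 1, on the same kind of position in the same words, and the cores of compound 3 and compound 2 differ only by methyl in place of chloro on an aromatic carbon.

Among the measured compounds shown here, the only precedent for this change is a 1.1-fold lower number from compound 2 to compound 1 (0.05 log units; within the scatter), which lies within the scatter. On that single precedent the expected step of a 1.1-fold lower number from compound 3 to compound 4 (0.02 log units; within the scatter) is also small, with no direction claimed. For the measured compounds named here, compound 4 is therefore estimated at 85000 nM in this assay, with the expected range running from 35000 nM to 200000 nM; the width reflects that only one earlier instance of this change exists and that it occurred on a different core.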

Compound 4, half-maximal cytotoxic concentration: 24000 nM
Estimate against measurement, compound 4: 3.5-fold (0.55 log units) above, and the stated range ends above it.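

Hydrogen in place of phenoxy does not carry over unchanged from one core to the other in this assay: on the methyl-bearing core it gives a 3.8-fold lower number from compound 3 to compound 4 (0.57 log units; beyond the scatter), and the comparison with the chloro-bearing core reads: the same change on two cores in this assay, a 1.1-fold lower number (0.05 log units; within the scatter) from compound 2 to compound 1 and a 3.8-fold lower number (0.57 log units; beyond the scatter) from compound 3 to compound 4, 3.4-fold (0.53 log units) apart, beyond the scatter of two such steps. Methyl in place of chloro likewise depends on what else is present, giving a 1.1-fold lower number from compound 1 to compound 4 (0.03 log units; within the scatter) without the phenoxy group, and the comparison with the step made with phenoxy in place reads: the same change on two cores in this assay, a 3.1-fold higher number (0.49 log units; beyond the scatter) from compound 2 to compound 3 and a 1.1-fold lower number (0.03 log units; within the scatter) from compound 1 to compound 4, 3.4-fold (0.53 log units) apart, beyond the scatter of two such steps. These two gaps come from the same four compounds and both turn on compound 3 at 90000 nM, so they amount to one observation that the two changes do not add, and they show neither why this happens nor whether any other core in the series behaves the same way.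

The compounds shown leave open whether the higher number of compound 3 needs phenoxy itself, or whether a smaller ether such as methoxy, or an amine, at that place would give a similar number alongside the methyl group. They also leave open how fluoro or methoxy in place of the chloro or methyl group would read, with and without phenoxy.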